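The source may hold more compounds than are shown below. What is called first, only, known or untested is meant among the compounds shown, and "the series" means these compounds.

Compound 1 `O=S(=O)(Nc1ccc(-c2nc3ccccc3o2)cc1)c1ccccc1Cl` gives in an assay on cells for inhibition of HSP60/HSP10 (Homo sapiens), with a stated time of 60 min (a higher number here means a weaker inhibitor, a lower number a stronger inhibitor), only a limit of the assay, > 100000 nM.
Compound 2 `Cc1ccccc1S(=O)(=O)Nc1ccc2oc(-c3ccccc3)nc2c1` gives in this assay only a limit, > 100000 nM.
Compound 3 `CS(=O)(=O)Nc1ccc(-c2nc3ccccc3o2)cc1` gives in this assay only a limit, > 100000 nM.

Compound 2 thus stands at the limit, and so do the two other values; the evidence is the limit of > 100000 nM in this assay, at which 3 of the 3 values shown sit. Compound 4 `O=S(=O)(Nc1ccc2oc(-c3ccccc3)nc2c1)c1ccccc1F` differs from compound 2 by fluoro in place of methyl on an aromatic carbon. Going by the values given here, the one measured single-point step, a step that the two limits leave unreadable from compound 1 to compound 3, cannot be read, since both of its ends are limits, so no measured step tells how large a change of this kind is in this assay. Compound 4 is therefore expected to stay at the limit as well, with an estimated step that the limit leaves unreadable from compound 2 to compound 4. The estimate for compound 4 is 200000 nM, ranging from 50000 nM to 1000000 nM.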

Compound 4, half-maximal inhibitory concentration: > 100000 nM
Compound 4: no number, only a limit; the forecaster's own chance of this, stated with the estimate: 85%; the middle value lies beyond the limit too.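

Compound 2 and compound 4 both give only a limit in this assay, so the step between them cannot be read. The compounds shown leave open which change, if any, would give a measurable number there.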